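The compounds below may be only part of what the source reports. "The series", "measured", "known", "first", "only" and "open" are said of these compounds alone.

Compound 1 (`C/C1=C\CC[C@@]2(C)O[C@@H]2[C@H]2OC(=O)[C@@H](CN3CCCC3)[C@@H]2C[C@H]1O`) gives 10000 nM in a functional assay on A549 cells (Homo sapiens) for inhibition, read by colorimetric assay and MTT assay, with a stated time of 72 h (on this read-out lower numbers stand for stronger inhibition and higher numbers for weaker inhibition), and cannot be told apart from compound 2 (`C/C1=C\CC[C@@]2(C)O[C@@H]2[C@H]2OC(=O)[C@@H](CN3CCCCC3)[C@@H]2C[C@H]1O`), which gives 18000 nM there. Compound 3 (`C/C1=C\CC[C@@]2(C)O[C@@H]2[C@H]2OC(=O)[C@@H](CN3CCN(C)CC3)[C@@H]2C[C@H]1O`) has 4-methylpiperazin-1-yl in place of pyrrolidin-1-yl on a saturated chain carbon bound to a saturated ring carbon. Among the compounds with values here, the one measured step that bears on this, a 1.8-fold higher number from compound 1 to compound 2 (0.26 log units; within the scatter) with piperidin-1-yl in place of pyrrolidin-1-yl, stays within the scatter. Within the data shown here, no measured compound carries 4-methylpiperazin-1-yl, so no step beyond the scatter is expected in this assay here. The estimated move is a 1.5-fold higher number from compound 1 to compound 3 (0.18 log units; within the scatter) and lies within the scatter. For compound 3 the expected value is 15000 nM (estimated range 6000 nM to 40000 nM).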

Compound 3, half-maximal inhibitory concentration: 30000 nM
Estimate against measurement, compound 3: 2.0-fold (0.30 log units) below, within the range that was stated.
By their numbers in this assay, from the lowest: compounds 1, 2 and 3 (each within the scatter of the next, the first and the last beyond it).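

Within the data shown here, this position responds to the choice of amine, though only modestly: 4-methylpiperazin-1-yl gives the first change that passes the scatter in this assay (a 3.0-fold higher number from compound 1 to compound 3 (0.48 log units; beyond the scatter)). Measured against the piperidin-1-yl of compound 2, the same group stays within the scatter (a 1.7-fold higher number from compound 2 to compound 3 (0.22 log units; within the scatter)), so only the two ends of this short series separate. No supporting data explain the step. 
Open, going by these compounds, is whether morpholin-4-yl or an open-chain dimethylamino group on this carbon would read like compound 1 or compound 3. A plain piperazin-1-yl would also show whether the methyl group matters.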